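This account rests on a few compounds, and the source may have more. Where it says the series, first, only, none or still open, it means among the compounds named here.

Compound 1 `CC(C(=O)N1CCN(c2ccccc2)CC1)N1C(=O)CCC1=O` gives 100% in a functional assay on the whole organism (strain Swiss) with Mus musculus as the target, in the maximal electroshock model, with a stated time of 0.25 h, at a dose of 300 mg/kg by the intraperitoneal route; a lower number here means a weaker effect, a higher number a stronger effect of the compound at the dose given. Among the measured compounds shown here, compound 2 `CCC(C(=O)N1CCN(c2ccc(F)cc2)CC1)N1C(=O)CCC1=O` gives 0% in this assay and stands lowest of the two numbers, with compound 1 a number higher by a gap beyond the scatter; no single step between them is drawn, as they differ in two places. Compound 3 `CC(C(=O)N1CCN(c2ccc(F)cc2)CC1)N1C(=O)CCC1=O` is compound 2 with hydrogen in place of methyl on a saturated chain carbon, two bonds along the chain from an amide-type nitrogen in a ring and a carbonyl carbon. An upward step beyond the scatter is expected, a number 75 percentage points higher from compound 2 to compound 3 (beyond the scatter), because compound 1 also carries hydrogen on that saturated chain carbon and gives 100%. Compound 3 is estimated at 75%, within 25% to 100%.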

Compound 3, a percentage reported as activity, at one dose (the size of the read-out at that dose, not a potency): 100%
Estimate against measurement, compound 3: 25 percentage points below; measured number inside the range.
By their numbers in this assay, from the lowest: compound 2; then compounds 1 and 3 (each within the scatter of the next).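

The step of a number 100 percentage points higher from compound 2 to compound 3 (beyond the scatter) in this assay shows that, with fluoro on the aromatic carbon, the read-out turns on ethyl to methyl at this saturated chain carbon. Fluoro in place of hydrogen on an aromatic carbon gives no change at the digits printed from compound 1 to compound 3 (within the scatter) and so does not set the read-out apart on the methyl compounds. Nothing available explains either step.

Open, on these data alone, is how a longer chain such as propyl, or a hydroxymethyl group, behaves on this chain carbon. Also open, as far as these compounds go, is whether chloro or methoxy in place of fluoro matches the step seen with fluoro.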